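A few compounds are considered here, and "the series" means these few. Any claim that something is new, unique, unknown or untested is made for them only; others in the source may bear on it.

Measured compounds in this series:
- compound 1, `CCN1CCC(COc2ccc(-c3nc4ccc(Oc5ccc(Cl)cc5)cc4o3)cc2)CC1`: 2.1%
- compound 2, `CC(C)N1CCC(COc2ccc(-c3nc4ccc(Oc5ccc(Cl)cc5)cc4o3)cc2)CC1`: 26.2%
- compound 3, `Clc1ccc(Oc2ccc3nc(-c4ccc(OCCCN5CCCC5)cc4)oc3c2)cc1`: "not active" (no number reported)

Among the measured compounds shown here, in an assay on isolated protein for inhibition of advanced glycosylation end product-specific receptor (Homo sapiens), read by FRET, with stated times of 30 min and 1 h, tested at 4 uM (a lower number here means less inhibition, a higher number more inhibition at the concentration tested (going by the name of the read-out)), compound 1 gives 2.1% and compound 2 gives 26.2%; the only single-point step measured so far is a number 24.1 percentage points higher from compound 1 to compound 2 (beyond the scatter). Compound 3 is reported in this assay as "not active" (no number reported), so no number stands for it; on the numbers shown it can be placed only as giving no measurable inhibition.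

Compound 4, `N[C@@H]1CCN(CCCOc2ccc(-c3nc4ccc(Oc5ccc(Cl)cc5)cc4o3)cc2)C1`, differs from compound 3 by amino in place of hydrogen on a saturated ring carbon. For the measured compounds named here, no measured step concerns an amino group on a saturated ring carbon; the one step in hand, a number 24.1 percentage points higher from compound 1 to compound 2 (beyond the scatter), concerns a methyl on a chain carbon and so does not bear on this change. The expectation therefore rests on compound 3 alone, whose read-out in this assay was "not active" (no number reported), and no step beyond the scatter is expected in this assay in either direction. Compound 4 is estimated at 8%, with a range from 0% to 30%.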

Compound 4, a percentage reported as inhibition, at one concentration (the size of the read-out at that concentration, not a potency): 19.6%
The estimate for compound 4 lay 11.6 percentage points below the measured number, and the stated range covers the measured number.
By their numbers in this assay, from the lowest: compound 1; then compounds 4 and 2 (each within the scatter of the next).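

Amino on the saturated ring carbon turns the pyrrolidin-1-yl compound reported as "not active" into one with a number: in this assay compound 3 reads "not active" (no number reported) and compound 4 reads 19.6%, but the step between them cannot be read, as compound 3 has no number. Against the piperidine compounds, the result reads as a number 6.6 percentage points lower from compound 2 to compound 4 (within the scatter) and as a number 17.5 percentage points higher from compound 1 to compound 4 (beyond the scatter), so in this assay the 2-(3-aminopyrrolidin-1-yl)ethyl group stands apart from 1-ethylpiperidin-4-yl but not from 1-isopropylpiperidin-4-yl. No evidence on the origin of these differences is available.

Open, on these data alone, is whether the opposite configuration at the amino-bearing ring carbon gives the same reading. Also open, as far as these compounds go, is whether a hydroxyl or a dimethylamino group in place of the amino, or a longer chain to the ring nitrogen, keeps the number.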